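The source may hold more compounds than are shown below. What is called first, only, known or untested is meant among the compounds shown, and "the series" means these compounds.

In a functional assay on HepG2 cells (Homo sapiens) for inhibition, read by scintillation counting, with a stated time of 2 h (on this read-out higher numbers stand for weaker inhibition and lower numbers for stronger inhibition), three compounds sharing one core have been examined so far. For compound 1 `CCCC(=O)N1CCC(N2CCN(C(=O)c3c(NC(=O)NCC)sc4ccccc34)CC2)CC1` the entry reads "not determined" (no result reported), so it offers no comparison. Compound 2 `CCNC(=O)Nc1sc2ccccc2c1C(=O)N1CCN(C2CCN(C(=O)OC3CCCCC3)CC2)CC1` gives 635 nM, and compound 3 `CCNC(=O)Nc1sc2ccccc2c1C(=O)N1CCN(C2CCN(C(=O)OC(C)(C)C)CC2)CC1` gives 79 nM, the lower of the two numbers and therefore the stronger inhibition. Compound 4 `CCNC(=O)Nc1sc2ccccc2c1C(=O)N1CCN(C2CCN(C(=O)NC(C)(C)C)CC2)CC1` has (tert-butyl)amino in place of tert-butoxy on a carbonyl carbon whose other neighbour is an amide-type nitrogen in a ring: (tert-butyl)amino in place of tert-butoxy on a carbonyl carbon.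

Going by the values given here, the one measured step, an 8.0-fold lower number from compound 2 to compound 3 (0.91 log units; beyond the scatter), exchanged cyclohexyl for tert-butyl and kept the oxygen. Among the compounds with values here, it shows that the numbers can move with a change in this part of the structure, but no measured step exchanges that oxygen for a nitrogen. With the tert-butyl group retained, only a small rise in the number is expected, close to the usual scatter. The expected change is a 1.6-fold higher number from compound 3 to compound 4 (0.22 log units; within the scatter). For compound 4 the estimated value is 130 nM, with an expected range of 35 nM to 500 nM.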

Compound 4, half-maximal inhibitory concentration: 775 nM
For compound 4 the middle estimate is 6.0-fold (0.78 log units) below the measured one; measured number above the stated range.
By their numbers in this assay, from the lowest: compound 3; then compounds 2 and 4 (each within the scatter of the next).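

In this assay, putting (tert-butyl)amino in place of tert-butoxy on a carbonyl carbon gives a 9.8-fold higher number from compound 3 to compound 4 (0.99 log units; beyond the scatter), so the low number of compound 3 depends on the linking atom as well as on the tert-butyl group. This exchange keeps the heavy-atom count and gains a hydrogen-bond donor while losing a hydrogen-bond acceptor, but no measurement available here accounts for the shift. The comparison with the cyclohexyl carbamate shows a 1.2-fold higher number from compound 2 to compound 4 (0.09 log units; within the scatter), so retaining the tert-butyl group did not by itself preserve the number of compound 3.

As far as these compounds go, it remains open whether a cyclohexylamino group on the same carbonyl carbon would behave like (tert-butyl)amino. Also open, from the compounds shown here alone, is how a (tert-butyl)(methyl)amino group, in which methyl replaces the amide hydrogen, would read in this assay.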